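The source may hold more compounds than are shown below. What is called first, only, known or untested is meant among the compounds shown, and "the series" means these compounds.

Working notes on the series. Compound 1 `O=S(=O)(NC1CCC2(OC1)c1ccccc1CCc1ccccc12)c1ccc(OC(F)(F)F)cc1` and compound 2 `O=S(=O)(NC1CCC2(OC1)c1ccccc1CCc1ccccc12)c1ccc(Cl)cc1` share one core; compound 3 `O=S(=O)(NC1CCOC2(C1)c1ccccc1CCc1ccccc12)c1ccc(OC(F)(F)F)cc1` and compound 4 `O=S(=O)(NC1CCOC2(C1)c1ccccc1CCc1ccccc12)c1ccc(Cl)cc1` share another. The difference between the two cores is not broken down here. In a functional assay on NCI-H1650 cells (Homo sapiens) for inhibition, read by MTT assay, with a stated time of 48 h (on this read-out higher numbers stand for weaker inhibition of growth and lower numbers for stronger inhibition of growth), compound 1 gives 13000 nM. In this assay compound 2 gives 25000 nM. The change between them is chloro in place of trifluoromethoxy on an aromatic carbon, and it made a 1.9-fold higher number from compound 1 to compound 2 (0.28 log units; within the scatter). For compound 3 this assay returns only a limit, > 40000 nM. That reading is the limit (the limit of > 40000 nM in this assay, at which 1 of the 3 values shown sits), not a number. Compound 4 carries the same kind of change on the second core, (chloro in place of trifluoromethoxy on an aromatic carbon), and the place is described in the same words as before. The step from compound 3 to compound 4 is expected to be about as small as the earlier one, a step that the limit leaves unreadable from compound 3 to compound 4, because the same change gave a 1.9-fold higher number from compound 1 to compound 2 (0.28 log units; within the scatter) on the first core. With compound 3 already at a limit, this assay is expected to report a limit again for compound 4 more often than a number. Compound 4 is estimated at 60000 nM, with a likely range from 30000 nM to 150000 nM.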

Compound 4, concentration for 50% growth inhibition: > 40000 nM
Compound 4: no number, only a limit; the forecaster's own chance of this, stated with the estimate: 80%; the middle value is on the limit's open side.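

In this assay compound 3 and compound 4 both return a limit and not a number, so no step can be read between them: the limit of > 40000 nM in this assay, at which 2 of the 4 values shown sit. The compounds shown leave open whether chloro in place of trifluoromethoxy has any readable size on the core of compound 3.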